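The source may report more compounds than this note shows. Statements on the series, on what has been measured and on what is new or still open speak of the compounds shown alone.

Compound 1 `COc1ccc(Cl)cc1N1CCN(CCNc2c(C(C)=O)c(-c3ccccc3)nn(C)c2=O)CC1`: 0.41 nM
Compound 2 `CC(=O)c1c(-c2ccccc2)nn(C)c(=O)c1NCCN1CCN(c2ccccc2F)CC1`: 0.49 nM

In an assay on isolated protein for binding affinity to Alpha-1D adrenergic receptor (Homo sapiens), read by radioligand binding (a higher number here means a weaker inhibitor, a lower number a stronger inhibitor), compound 2 gives 0.49 nM, the higher of the two numbers, though the step of a 1.2-fold higher number from compound 1 to compound 2 (0.08 log units; within the scatter) lies within the scatter. Compound 3 `CC(=O)c1c(-c2ccccc2)nn(C)c(=O)c1NCCN1CCN(c2ccccc2Cl)CC1` differs from compound 2 by chloro in place of fluoro on an aromatic carbon. Within the data shown here, the only step that bears on this, a 1.2-fold higher number from compound 1 to compound 2 (0.08 log units; within the scatter), exchanged the whole aryl group on the amine nitrogen in the ring and stayed within the scatter, so a single halogen swap at the same aromatic carbon is expected to give no step beyond the scatter. The expected step is a 1.0-fold higher number from compound 2 to compound 3 (0.01 log units; within the scatter). Compound 3 is therefore expected to give 0.5 nM, with a range from 0.2 nM to 1.3 nM.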

Compound 3, inhibition constant: 0.25 nM
Compound 3: the middle estimate sits 2.0-fold (0.30 log units) above what was measured, within the range that was stated.
By their numbers in this assay, from the lowest: compounds 3, 1 and 2 (each within the scatter of the next).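

In this assay, 2-chlorophenyl and 2-fluorophenyl, with the halogen ortho to a large group, cannot be told apart, with a 2.0-fold lower number from compound 2 to compound 3 (0.29 log units; within the scatter), so this single-atom exchange at this position stays within the scatter. Replacing the 5-chloro-2-methoxyphenyl group with 2-chlorophenyl gives a 1.6-fold lower number from compound 1 to compound 3 (0.21 log units; within the scatter), so this change at the ring amine nitrogen also stays within the scatter. Nothing available here explains these numbers. From the compounds shown here alone, whether a bromo, methyl or nitrile at this aromatic carbon would also stay within the scatter remains open. So does the effect of an unsubstituted phenyl in place of these aryl groups.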